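The source may report more compounds than this note shows. Statements on the series, on what has been measured and on what is new or still open speak of the compounds shown alone.

Working notes on the series. In a functional assay on cells (Cancer cell lines, Homo sapiens) for cytotoxicity, read by sulforhodamine B assay, with a stated time of 48 h (a higher number here means a weaker inhibitor of growth, a lower number a stronger inhibitor of growth), compound 3 `COc1ccc(C2=NN(C3=NC(=O)/C(=C4\C(=O)Nc5ccccc54)S3)C(c3ccc(Cl)cc3)C2)cc1` gives 77500 nM, the highest of the three numbers in hand. Compound 1 `COc1ccc(C2=NN(C3=NC(=O)/C(=C4\C(=O)Nc5ccc(Br)cc54)S3)C(c3ccc(OC)cc3)C2)cc1` gives 200 nM and compound 2 `O=C1N=C(N2N=C(c3ccccc3)CC2c2ccc(Cl)cc2)S/C1=C1/C(=O)Nc2ccccc21` gives 190 nM. Among the compounds with values here, the only measured single-point step is a 410-fold higher number from compound 2 to compound 3 (2.61 log units; beyond the scatter). Compound 4 `COc1ccc(C2=NN(C3=NC(=O)/C(=C4\C(=O)Nc5ccc(Br)cc54)S3)C(c3ccc(Cl)cc3)C2)cc1` differs from compound 3 by bromo in place of hydrogen on an aromatic carbon. Within the data shown here, no measured step concerns this particular change; compound 1 carries the same bromo group but also differs from compound 3 at a second position, so its value can only be noted alongside that of compound 3, not used as a direct precedent. With that uncertainty, a step of a 13-fold lower number from compound 3 to compound 4 (1.11 log units; beyond the scatter) is expected, toward a lower number, with a wide range. Compound 4 is therefore estimated at 6000 nM, between 400 nM and 60000 nM.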

Compound 4, concentration for 50% growth inhibition: 120 nM
For compound 4 the middle estimate is 50-fold (1.70 log units) above the measured one; measured number below the stated range.
By their numbers in this assay, from the lowest: compounds 4, 2 and 1 (each within the scatter of the next); then compound 3.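

In this assay, bromo in place of hydrogen on an aromatic carbon of the fused system gives a 650-fold lower number from compound 3 to compound 4 (2.81 log units; beyond the scatter), the first measured sign that this position strongly governs the read-out. With bromo present, chloro in place of methoxy gives a 1.7-fold lower number from compound 1 to compound 4 (0.22 log units; within the scatter), so that exchange stays within the scatter. No available evidence explains the size of the bromo step. As far as these compounds go, it remains open whether fluoro or an amine at this position would match bromo, and whether bromo would matter in the methoxy-free compound 2.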